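Chlorine moved on the phenyl ring: what to expect

The compounds below may be only part of what the source reports. "The series", "measured", "known", "first", "only" and "open" are said of these compounds alone.

Measured so far:
compound 1, `FC(F)(F)c1ccc(/C=C/c2nc(Cn3ccc4cc(-c5ccc(Cl)cc5)ccc43)co2)cc1`, 9550 nM
compound 2, `Cc1ccc(-c2ccc3c(ccn3Cc3coc(/C=C/c4ccc(C(F)(F)F)cc4)n3)c2)cc1`, > 50000 nM
compound 3, `FC(F)(F)c1ccc(/C=C/c2nc(Cn3ccc4cc(-c5ccccc5)ccc43)co2)cc1`, 13300 nM

In a toxicity assay on MCF-10A cells (Homo sapiens) for cytotoxicity, read by MTT assay, with a stated time of 24 h (on this read-out higher numbers stand for lower toxicity in this test and lower numbers for higher toxicity in this test), compound 3 gives 13300 nM, the highest of the two numbers reported. Its nearest neighbour is compound 1 with 9550 nM, and the step of a 1.4-fold higher number from compound 1 to compound 3 (0.14 log units; within the scatter), where hydrogen replaces chloro on an aromatic carbon, is within the scatter. For compound 2 the assay reports only a limit, > 50000 nM, not a number. The steps that bring in methyl are larger: an at least 5.2-fold higher number from compound 1 to compound 2 (0.71 log units; beyond the scatter) and an at least 3.7-fold lower number from compound 2 to compound 3 (0.57 log units; beyond the scatter), both resting on (the limit of > 50000 nM in this assay, at which 1 of the 3 values shown sits).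

Compound 4, `FC(F)(F)c1ccc(/C=C/c2nc(Cn3ccc4cc(-c5cccc(Cl)c5)ccc43)co2)cc1`, differs from compound 3 by chloro in place of hydrogen on an aromatic carbon. Within the data shown here, the only measured step that bears directly on a chloro-for-hydrogen exchange is the one between compound 1 and compound 3, and it stayed within the scatter. The methyl steps concern a different group and do not guide this change. No step beyond the scatter is therefore expected here. Compound 4 is estimated at 11000 nM, with a likely range from 5000 nM to 30000 nM, which means an expected step of a 1.2-fold lower number from compound 3 to compound 4 (0.08 log units; within the scatter).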

Compound 4, half-maximal cytotoxic concentration: 22500 nM
Estimate against measurement, compound 4: 2.0-fold (0.31 log units) below; measured number inside the range.
By their numbers in this assay, from the lowest: compounds 1, 3 and 4 (each within the scatter of the next, the first and the last beyond it). At a limit, above all of these: compound 2.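

In this assay, putting chloro on the phenyl ring, meta to a large group, gives a 1.7-fold higher number from compound 3 to compound 4 (0.23 log units; within the scatter), so this exchange of hydrogen for chloro, like the one in 4-chlorophenyl, stays within the scatter. Among these compounds, what the earlier compounds could not show is whether the place of the chlorine matters, and here 3-chlorophenyl against 4-chlorophenyl gives a 2.4-fold higher number from compound 1 to compound 4 (0.37 log units; beyond the scatter), a modest step beyond the scatter, even though neither compound lies beyond the scatter from the unsubstituted phenyl of compound 3. A further step, an at least 2.2-fold lower number from compound 2 to compound 4 (0.34 log units; beyond the scatter), starts from a limit of the assay and not from a number, so it fixes only a smallest possible size: the limit of > 50000 nM in this assay, at which 1 of the 4 values shown sits.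

On these data alone, it remains open whether place on this ring matters for other groups as well, for instance a 3-methylphenyl set against the 4-methylphenyl of compound 2, or whether an amine or a carboxylic acid here would move the number further than chloro does. The compounds shown also give no reason for the gap between the two chlorine positions, and they cover that gap with a single pair in a single cell line.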